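Chain double bond carried across two linker variants

A few compounds are considered here, and "the series" means these few. Any claim that something is new, unique, unknown or untested is made for them only; others in the source may bear on it.

Compound 1 `CCCCCCCC/C=C\CCCCCCCCNC(=O)Nc1c(OC)cc(OC)cc1OC`: 320 nM
Compound 2 `CCCCCCCCCCCCCCCCCCNC(=O)Nc1c(OC)cc(OC)cc1OC`: 900 nM
Compound 3 `CCCCCCCCCCCCCCCCCCOC(=O)Nc1c(OC)cc(OC)cc1OC`: 7100 nM

All numbers come from an assay on microsomes from intestinal mucosa for inhibition of acyl-CoA:cholesterol acyltransferase (Oryctolagus cuniculus); a higher number here means a weaker inhibitor, a lower number a stronger inhibitor. Compound 3 gives the highest number of the three; how its core differs from the core of compound 2 is not broken down here. Within the core of compound 2, dec-1-en-1-yl in place of decyl on a saturated chain carbon, eight bonds along the chain from an amide-type nitrogen gave a 2.8-fold lower number from compound 2 to compound 1 (0.45 log units; beyond the scatter). Compound 4 `CCCCCCCC/C=C\CCCCCCCCOC(=O)Nc1c(OC)cc(OC)cc1OC` carries the same kind of change on the core of compound 3: dec-1-en-1-yl in place of decyl on a saturated chain carbon, eight bonds along the chain from an oxygen next to a carbonyl group. The place differs in its printed words, eight bonds along the chain from an oxygen next to a carbonyl group rather than from an amide-type nitrogen. Within the data shown here, for compound 4 a step of similar size is expected, a 2.8-fold lower number from compound 3 to compound 4 (0.45 log units; beyond the scatter), because a 2.8-fold lower number from compound 2 to compound 1 (0.45 log units; beyond the scatter) is the only measured instance of this kind of change. The estimate for compound 4 in this assay is 2500 nM, with a range from 1200 nM to 5500 nM.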

Compound 4, half-maximal inhibitory concentration: 860 nM
Beside the measured number, compound 4's estimate is 2.9-fold (0.46 log units) above it; measured number below the stated range.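

In this assay, dec-1-en-1-yl in place of decyl on the core of compound 3 gives an 8.3-fold lower number from compound 3 to compound 4 (0.92 log units; beyond the scatter), so the number falls on both cores shown. The direction carries over from one core to the other, but the size does not: the same change on two cores in this assay, a 2.8-fold lower number (0.45 log units; beyond the scatter) from compound 2 to compound 1 and an 8.3-fold lower number (0.92 log units; beyond the scatter) from compound 3 to compound 4, 2.9-fold (0.47 log units) apart, beyond the scatter of two such steps

Two pairs give no rule for predicting the size on a further core, and they do not explain why the two steps differ. The compounds shown leave open whether a longer chain or a second double bond would give steps in the same direction on both cores. They also leave open how the change would behave on a core with a sulfur atom in place of the oxygen next to the carbonyl group.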